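Swapping the Dibromophenyl Group on a Fused Core

This account rests on a few compounds, and the source may have more. Where it says the series, first, only, none or still open, it means among the compounds named here.

Compound 2 `CCCCN(CC)c1cc(C)nc2c1NC(=O)CN2c1ccc(Br)cc1Br` gives 1.3 nM in an assay on HEK-293T cells for displacement of a labelled ligand from corticotropin-releasing factor receptor 1 (Homo sapiens), read by scintillation counting, with a stated time of 2 h (on this read-out lower numbers stand for stronger inhibition and higher numbers for weaker inhibition), the lowest of the two numbers recorded; its nearest neighbour, compound 1 `CCCCN(CC)c1cc(C)nc2c1NC(=O)CN2c1ccc(C(C)(C)C)cc1Br`, gives 4.2 nM in this assay. Among the measured compounds shown here, the only measured step, a 3.2-fold lower number from compound 1 to compound 2 (0.51 log units; beyond the scatter), shows a modest gain beyond the scatter. Compound 3 `CCCCN(CC)c1cc(C)nc2c1NC(=O)CN2c1ccc(I)cc1C` is the next to be measured. Its difference from compound 2 is 4-iodo-2-methylphenyl in place of 2,4-dibromophenyl on a nitrogen on an aromatic ring in a ring. For the measured compounds named here, no measured step covers this exact change: the step from compound 1 to compound 2 exchanged tert-butyl for bromo at a single carbon, whereas here both substituents of the ring change, one bromo becoming iodo and the other becoming methyl. Going by the values given here, compound 3 is therefore expected to show a 1.9-fold higher number from compound 2 to compound 3 (0.28 log units; within the scatter), most likely within the scatter, because compound 2 gives 1.3 nM and no measured step points to a clear shift. Compound 3 is estimated at 2.5 nM, between 0.8 nM and 8 nM.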

Compound 3, inhibition constant: 3.4 nM
Estimate against measurement, compound 3: 1.4-fold (0.13 log units) below; the range from low to high includes it.
By their numbers in this assay, from the lowest: compound 2; then compounds 3 and 1 (each within the scatter of the next).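

In this assay, placing 4-iodo-2-methylphenyl on this nitrogen in place of 2,4-dibromophenyl gives a 2.6-fold higher number from compound 2 to compound 3 (0.42 log units; beyond the scatter), a modest loss of binding strength. The earlier step altered one substituent on this aryl group, whereas this change replaces both bromo substituents at once, keeping the count of 8 heavy atoms, and compound 3 still reads 3.4 nM. The data therefore show that this position accepts a methyl and an iodo together at a small cost, but nothing given here explains the rise.

With both substituents changed together, the compounds shown do not separate the part played by the iodo from that played by the methyl. They also leave open how a methoxy group or an amine would read on this aryl group.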